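The compounds below may be only part of what the source reports. "The series", "measured", "known", "first", "only" and "open" are said of these compounds alone.

Compound 1 `NS(=O)(=O)c1ccc(COc2ccc(CNC(=O)[C@@H]3CCC(=O)N3Cc3ccccc3)cc2)cc1` — in an assay on HEK293 cells for inhibition of Ataxin-2 (Mus musculus), read by fluorescence and Amplex Red (a higher number here means a weaker inhibitor, a lower number a stronger inhibitor), compound 1 gives > 5000 nM, which is a limit of the assay rather than a number.
Compound 2 `O=C(O)c1ccc(COc2ccc(CNC(=O)[C@@H]3CCC(=O)N3Cc3ccccc3)cc2)cc1` — in this assay compound 2 gives 4500 nM.
Compound 3 `O=C(NO)c1ccc(COc2ccc(CNC(=O)[C@@H]3CCC(=O)N3Cc3ccccc3)cc2)cc1` — in this assay compound 3 gives 700 nM.

Compound 3 holds the lowest of the two numbers shown. Its nearest neighbour is compound 2, with a 6.4-fold lower number from compound 2 to compound 3 (0.81 log units; beyond the scatter), and against compound 1 the gap is an at least 7.1-fold lower number from compound 1 to compound 3 (0.85 log units; beyond the scatter), compound 1 sitting at the limit of > 5000 nM in this assay, at which 1 of the 3 values shown sits. The step from compound 1 to compound 2, an at least 1.1-fold lower number from compound 1 to compound 2 (0.04 log units; that floor lies within the scatter), stays within the scatter.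

Compound 4 `O=C(NCc1ccc(O)cc1)[C@@H]1CCC(=O)N1Cc1ccccc1` differs from compound 3 by hydrogen in place of 4-(hydroxycarbamoyl)benzyl on an oxygen on an aromatic ring. Going by the values given here, no measured step removes this group outright; the closest guide is the exchange at the carbonyl carbon, where the hydroxyamino end carried the improvement from compound 2 to compound 3. With that end and the benzyl that holds it both gone, the number for compound 4 is expected to rise, most likely back toward the limit of the assay, an expected step of an 11-fold higher number from compound 3 to compound 4 (1.06 log units; beyond the scatter). The estimate for compound 4 is 8000 nM, within a range from 2000 nM to 30000 nM.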

Compound 4, half-maximal inhibitory concentration: > 5000 nM
Compound 4 was reported as a limit (the forecaster's own chance of this, stated with the estimate: 60%); the middle value is on the limit's open side.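

Hydrogen in place of 4-(hydroxycarbamoyl)benzyl on the oxygen gives an at least 7.1-fold higher number from compound 3 to compound 4 (0.85 log units; beyond the scatter), which shows that the reading of compound 3 in this assay is not held by the shared core once this group is gone. The same position carrying 4-carboxybenzyl gives only an at least 1.1-fold higher number from compound 2 to compound 4 (0.04 log units; that floor lies within the scatter), so that exchange shows no difference from compound 2 that can be claimed. The value of compound 4 is a limit and not a number, and the step from compound 1 to compound 4 cannot be read: the limit of > 5000 nM in this assay, at which 2 of the 4 values shown sit.

The compounds shown do not separate what the benzyl ring contributes from what the hydroxycarbamoyl end contributes. As far as these compounds go, whether a plain benzyl on that oxygen, or a hydroxycarbamoyl group on a longer chain, would keep any of the reading of compound 3 stays open.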